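Trifluoromethyl step on the aryl ring, cytotoxicity notes

The source may report more compounds than this note shows. Statements on the series, on what has been measured and on what is new or still open speak of the compounds shown alone.

Measured compounds:
- compound 1 `CCOC(=O)C1=C(C)N/C(=C/c2cc(C)n(Cc3ccc(C(F)(F)F)cc3)c2C)C1=O`: 72000 nM
- compound 2 `CCOC(=O)C1=C(C)N/C(=C/c2cc(C)n(Cc3ccccc3)c2C)C1=O`: 50000 nM
- compound 3 `CCOC(=O)C1=C(C)N/C(=C/c2c(C)nn(-c3ccccc3)c2Cl)C1=O`: 13000 nM

In an ADME assay on L6 cells (Rattus norvegicus) for cytotoxicity, read by resazurin assay, with a stated time of 72 h (a higher number here means that more compound is needed for the effect, a lower number that less compound is needed), compound 2 gives 50000 nM and compound 1 gives 72000 nM. The step between them is a 1.4-fold higher number from compound 2 to compound 1 (0.16 log units; within the scatter), and the change behind it is trifluoromethyl in place of hydrogen on an aromatic carbon. Compound 3, which carries a different core, gives 13000 nM in this assay; the difference between the core of compound 3 and the core of compound 2 is not broken down here. Among the three measured compounds, compound 3 holds the lowest number, with the steps to compound 2 and to compound 1 both beyond the scatter.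

Compound 4 `CCOC(=O)C1=C(C)N/C(=C/c2c(C)nn(-c3ccc(C(F)(F)F)cc3)c2Cl)C1=O` is not yet measured in this assay. It differs from compound 3 by trifluoromethyl in place of hydrogen on an aromatic carbon, the same kind of change as from compound 2 to compound 1; both place lines read the same. Among the compounds with values here, the only guide for its size is the earlier step, which stayed within the scatter, so a step of similar size is expected here, a 1.2-fold higher number from compound 3 to compound 4 (0.09 log units; within the scatter), resting on a 1.4-fold higher number from compound 2 to compound 1 (0.16 log units; within the scatter) and starting from the number of compound 3, 13000 nM. Within the data shown here, whether the core of compound 3 answers this change in the same way as the core of compound 2 cannot be checked from the data in hand; only one earlier instance exists.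

For compound 4 the estimate in this assay is 16000 nM, with a range from 6000 nM to 45000 nM.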

Compound 4, half-maximal effective concentration: 42000 nM
Compound 4: the middle estimate sits 2.6-fold (0.42 log units) below what was measured, and the stated range covers the measured number.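

In this assay, trifluoromethyl in place of hydrogen, here phenyl to 4-(trifluoromethyl)phenyl, gives a 3.2-fold higher number from compound 3 to compound 4 (0.51 log units; beyond the scatter), and set beside the earlier instance of the same change, the two steps cannot be told apart: the same change on two cores in this assay, a 1.4-fold higher number (0.16 log units; within the scatter) from compound 2 to compound 1 and a 3.2-fold higher number (0.51 log units; beyond the scatter) from compound 3 to compound 4, 2.2-fold (0.35 log units) apart, within the scatter of two such steps The change can therefore be carried from the core of compound 2 to the core of compound 3 with no measurable difference in the size of its step, although only the step on the core of compound 3 lies beyond the scatter, so a real shift in the number is shown on that core alone. Two pairs do not establish a rule for the series, and they neither prove that the two cores answer identically nor explain why the change acts as it does.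

The compounds shown leave open whether a different group on the same aromatic carbon, such as a carboxylic acid, an amine or a methoxy group, would move the number on either core. They also leave open whether a third core would give a step of similar size for trifluoromethyl, which would be needed before the change could be treated as transferable across the series.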